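This account rests on a few compounds, and the source may have more. Where it says the series, first, only, none or still open, it means among the compounds named here.

Compound 1, `COc1nc(C2=NOCC(c3ccc(Cl)cc3)N2)ccc1-n1cnc(C)c1`, is the starting point of this step. Among the compounds with values here, in an ADME assay on cells (Hepatocyte, Homo sapiens) for pharmacokinetics (on this read-out lower numbers stand for slow clearance and higher numbers for fast clearance), compound 1 gives 2 mL/min/kg, the lowest of the three numbers measured so far. Its nearest neighbour is compound 2, `COc1nc(C2=NOCC(c3ccc(C)cc3)N2)ccc1-n1cnc(C)c1`, which in this assay gives 135 mL/min/kg, and the furthest is compound 3, `COc1nc(C2=NOCC(c3ccc(C(C)(C)C)cc3)N2)ccc1-n1cnc(C)c1`, which gives 320 mL/min/kg. The measured steps are a 68-fold higher number from compound 1 to compound 2 (1.83 log units; beyond the scatter), a 160-fold higher number from compound 1 to compound 3 (2.20 log units; beyond the scatter) and a 2.4-fold higher number from compound 2 to compound 3 (0.37 log units; beyond the scatter); each of the first two swaps out the chloro group for a small carbon group, and each raises the number a great deal.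

Compound 4, `COc1nc(C2=NOCC(c3ccc(Cl)c(C(F)(F)F)c3)N2)ccc1-n1cnc(C)c1`, keeps the chloro group and differs from compound 1 in only one place: trifluoromethyl in place of hydrogen on an aromatic carbon. Within the data shown here, no measured step adds a group while leaving the chloro in place, so none of them bears directly on this change; the two large steps only show that the chloro was the feature behind the low number of compound 1, and that feature stays. The step expected here is therefore small, a 1.5-fold higher number from compound 1 to compound 4 (0.18 log units; within the scatter), with the number staying low. For compound 4 the estimate is 3 mL/min/kg, with a likely range from 1 mL/min/kg to 10 mL/min/kg.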

Compound 4, clearance: 6 mL/min/kg
Beside the measured number, compound 4's estimate is 2.0-fold (0.30 log units) below it, and the stated range covers the measured number.
By their numbers in this assay, from the lowest: compound 1; then compound 4; then compound 2; then compound 3.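

In this assay, adding trifluoromethyl on an aromatic carbon ortho to a chloro group gives a 3.0-fold higher number from compound 1 to compound 4 (0.48 log units; beyond the scatter) as a modest step beyond the scatter, so a change at this position of the ring does register in the read-out. With the chloro group kept, compound 4 still gives 6 mL/min/kg and stays well below the other two compounds, and this step is far smaller than the one seen on replacing the chloro group, a 68-fold higher number from compound 1 to compound 2 (1.83 log units; beyond the scatter) in the clearest case. No evidence is available on why the number rises with this added group.

The compounds shown leave open whether a single fluorine, a methoxy group, an amine or a carboxylic acid at this same position would move the number less, more or in the other direction. They also leave open whether trifluoromethyl at this position would give a step of similar size on the methyl or tert-butyl compounds, whose numbers start much higher, or with no chloro group on the ring at all.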